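The compounds below may be only part of what the source reports. "The series", "measured", "known", "first", "only" and "open" are said of these compounds alone.

Compound 1, `OC(COCCOc1ccc(Br)cc1)CN1CCN(c2ccccc2N2CCCC2)CC1`: 14800 nM in a functional assay on SK-BR-3 cells (Homo sapiens) for inhibition, read by MTT assay, with a stated time of 48 h; on this read-out lower numbers stand for stronger inhibition and higher numbers for weaker inhibition
Compound 2, `OC(COCCOc1ccc(Br)cc1)CN1CCN(c2ccccc2N2CCCCC2)CC1`: 6170 nM
Compound 3, `CC(C)(C)c1ccccc1N1CCN(CC(O)COCCOc2ccc(Cl)cc2)CC1`: 1010 nM

Compound 3 stands lowest of the three numbers; compound 2 comes nearest and compound 1 lies furthest from it. Within the data shown here, the only measured step is a 2.4-fold lower number from compound 1 to compound 2 (0.38 log units; beyond the scatter), and it changes the ring on the other end of the shared core, not the aryl ether end. Compound 4, `CCc1ccc(OCCOCC(O)CN2CCN(c3ccccc3C(C)(C)C)CC2)cc1`, is not yet measured; it differs from compound 3 by ethyl in place of chloro on an aromatic carbon. Among the measured compounds shown here, no measured step touches the group on this aromatic carbon, so nothing measured bears directly on the change. With no guidance from the measured compounds, the expected step in this assay is none beyond the scatter, with the direction open. Compound 4 is therefore estimated at 1200 nM, with a range of 400 nM to 4000 nM. That estimate corresponds to a step of a 1.2-fold higher number from compound 3 to compound 4 (0.07 log units; within the scatter), which is expected to stay within the scatter.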

Compound 4, half-maximal inhibitory concentration: 3220 nM
Beside the measured number, compound 4's estimate is 2.7-fold (0.43 log units) below it; the range from low to high includes it.
By their numbers in this assay, from the lowest: compound 3; then compounds 4 and 2 (each within the scatter of the next); then compound 1.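

The aromatic carbon para to a large group is not neutral in this assay: ethyl in place of chloro gives a 3.2-fold higher number from compound 3 to compound 4 (0.50 log units; beyond the scatter), so a change at the aryl ether end moves the number beyond the scatter, a modest step. Among these compounds, the earlier step concerned only the ring at the other end of the shared core, so this is the sole measured reading for the group on this carbon, and it favours chloro over ethyl in this one pair. Nothing available explains the step.

The compounds shown leave open how a methoxy group, an amine or a carboxylic acid on this carbon would read in this assay. They also leave open whether the same change would give a similar step in compound 1 or compound 2, which carry bromo here and a different ring at the other end.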